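This account rests on a few compounds, and the source may have more. Where it says the series, first, only, none or still open, it means among the compounds named here.

Compound 2 `O=C(Nc1cc(C(F)(F)F)cc(C(F)(F)F)c1)C1CCc2ccccc2N1C(=O)c1ccc(Cl)cc1` carries a 4-chlorophenyl carbonyl on the ring nitrogen. In a functional assay on NUGC-3 cells (Homo sapiens) for cytotoxicity, read by sulforhodamine B assay, with a stated time of 72 h (a lower number here means a stronger inhibitor of growth, a higher number a weaker inhibitor of growth), compound 2 gives 1660 nM. Among the three measured compounds its number sits beyond the scatter below that of compound 1 `CCCCCCCCC(=O)N1c2ccccc2CCC1C(=O)Nc1ccccc1C(F)(F)F`, which in this assay gives 6180 nM, and within the scatter of compound 3 `O=C(Nc1ccccc1O)C1CCc2ccccc2N1`, which in this assay gives 2680 nM. Among the measured compounds shown here, no two measured compounds differ in one place, so no step size is known from them.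

Compound 4 `CC(=O)N1c2ccccc2CCC1C(=O)Nc1cc(C(F)(F)F)cc(C(F)(F)F)c1` is compound 2 with methyl in place of 4-chlorophenyl on a carbonyl carbon. Compound 1, with an alkyl acyl on the same nitrogen, gives the weakest number shown, so the expected step from compound 2 to compound 4 is a modest rise, a 2.4-fold higher number from compound 2 to compound 4 (0.38 log units; beyond the scatter), though it may fall within the scatter. For compound 4 the estimate in this assay is 4000 nM, expected between 1500 nM and 12000 nM.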

Compound 4, concentration for 50% growth inhibition: > 70000 nM
Compound 4 was reported as a limit (the forecaster's own chance of this, stated with the estimate: 5%); at least 17-fold (1.24 log units) between middle value and limit.
By their numbers in this assay, from the lowest: compounds 2 and 3 (each within the scatter of the next); then compound 1. At a limit, above all of these: compound 4.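

In this assay, this first one-place step in the series shows that the group on this carbonyl carbon matters greatly: an at least 42-fold higher number from compound 2 to compound 4 (1.62 log units; beyond the scatter). Compound 4 is reported only as a limit, > 70000 nM. The true size of the step therefore remains unknown, and the step gives only its minimum: the limit of > 70000 nM in this assay, at which 1 of the 4 values shown sits.

Going by these compounds, whether the loss follows the ring or the chlorine remains open, since 4-chlorophenyl left as a whole. An unsubstituted phenyl, a cyclohexyl or a propyl chain on the same carbonyl carbon would separate these parts.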